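Aryl hydrazone acids: from compound 3 to compound 4

A few compounds are considered here, and "the series" means these few. Any claim that something is new, unique, unknown or untested is made for them only; others in the source may bear on it.

Measured in a functional assay (mast cells) for inhibition, with Rattus norvegicus as the target; a higher number here means that more compound is needed for the effect, a lower number that less compound is needed:
- compound 1 `CC1CC/C(=N\Nc2cccc(Cl)c2)c2ncc(C(=O)O)c(=O)n21`: 311000 nM
- compound 2 `CC1CC/C(=N\Nc2cccc(Br)c2)c2ncc(C(=O)O)c(=O)n21`: 6700 nM
- compound 3 `COc1ccc(N/N=C2\CCC(C)n3c2ncc(C(=O)O)c3=O)cc1`: 128000 nM

Compound 3, at 128000 nM, holds the second highest of the three numbers. Its nearest measured neighbour is reached by a 2.4-fold lower number from compound 1 to compound 3 (0.39 log units; beyond the scatter), and its furthest by a 19-fold higher number from compound 2 to compound 3 (1.28 log units; beyond the scatter).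

The next compound is compound 4 `Cc1cccc(N/N=C2\CCC(C)n3c2ncc(C(=O)O)c3=O)c1`, with 3-methylphenyl in place of 4-methoxyphenyl on an amine nitrogen.

Within the data shown here, no measured compound carries a methyl group on the aryl ring, so no step transfers directly. Among the measured compounds shown here, compound 1 and compound 2 are the closest comparisons, yet their single exchange of halogen already gives a 46-fold lower number from compound 1 to compound 2 (1.67 log units; beyond the scatter), a large step. Aryl changes in this small set therefore range from modest to large, and their direction is not consistent. The expectation for compound 4 is a value inside the span set by compound 1 and compound 2, near the middle of that span on a logarithmic scale. The expected step is a 2.6-fold lower number from compound 3 to compound 4 (0.41 log units; beyond the scatter), a modest move toward a lower number.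

For compound 4 the estimated value in this assay is 50000 nM, with an expected range of 7000 nM to 300000 nM.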

Compound 4, half-maximal effective concentration: 72900 nM
The estimate for compound 4 lay 1.5-fold (0.16 log units) below the measured number; the measured number falls inside the stated range.
By their numbers in this assay, from the lowest: compound 2; then compounds 4 and 3 (each within the scatter of the next); then compound 1.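

In this assay, 3-methylphenyl in place of 4-methoxyphenyl on an amine nitrogen gives a 1.8-fold lower number from compound 3 to compound 4 (0.24 log units; within the scatter), so this exchange, which takes an oxygen out of the aryl group, does not separate the two compounds in this assay. The methyl group also gives the first non-halogen comparison on that aromatic carbon, and the outcome depends on the halogen it replaces: against bromo it gives an 11-fold higher number from compound 2 to compound 4 (1.04 log units; beyond the scatter), while against chloro it gives a 4.3-fold lower number from compound 1 to compound 4 (0.63 log units; beyond the scatter), which leaves compound 4 on the opposite side of each halogen and keeps the bromo compound 2 apart from the other three compounds shown. No independent measurement bears on the reason for these differences.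

On these data alone, whether the low number of compound 2 is particular to bromo stays open, as fluoro, iodo or trifluoromethyl on the same aromatic carbon could fall with either halogen or with neither. Also open, as far as these compounds go, is whether the difference between bromo and methyl persists when the carboxylic acid of the shared core is exchanged for a methyl ester or an amide.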